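Series notes: thiophen-2-yl to pyridin-3-yl exchange

The source may hold more compounds than are shown below. What is called first, only, known or untested is meant among the compounds shown, and "the series" means these compounds.

Measured so far in an in vitro assay on BTI-TN-5B1-4 cells for inhibition of Amine oxidase [flavin-containing] A (Homo sapiens), read by Amplex Red, with a stated time of 15 min, tested at 100 uM; a higher number here means more inhibition at the concentration tested (going by the name of the read-out), a lower number less inhibition:
compound 1, `C/C(=N/Nc1nc(-c2ccc(F)cc2)cs1)c1cccs1`, gives 40%
compound 2, `C/C(=N/Nc1nc(-c2ccc(F)cc2)cs1)c1cccnc1`, gives 40%
compound 3, `C/C(=N/Nc1nc(-c2ccc(F)cc2F)cs1)c1cccs1`, gives 40%

The change pyridin-3-yl in place of thiophen-2-yl on a carbon with a double bond to nitrogen is made once among the measured compounds, and its step is no change at the digits printed from compound 1 to compound 2 (within the scatter). The cores of compound 1 and compound 3 differ by fluoro in place of hydrogen on an aromatic carbon, with the step of no change at the digits printed from compound 1 to compound 3 (within the scatter). All three measured values sit level within the scatter, so no order can be read among them.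

Compound 4, `C/C(=N/Nc1nc(-c2ccc(F)cc2F)cs1)c1cccnc1`, is not yet measured. Its difference from compound 3 is pyridin-3-yl in place of thiophen-2-yl on a carbon with a double bond to nitrogen, and the two "place" descriptions agree word for word, so this is the same change as from compound 1 to compound 2. The expected step is no change at the digits printed from compound 3 to compound 4 (within the scatter), set beside no change at the digits printed from compound 1 to compound 2 (within the scatter), because that earlier step stayed within the scatter and the fluoro change no change at the digits printed from compound 1 to compound 3 (within the scatter) also left the value unmoved. On that basis compound 4 is estimated at 40% in this assay, with an expected range from 25% to 55%.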

Compound 4, a percentage reported as inhibition, at one concentration (the size of the read-out at that concentration, not a potency): 40%
Compound 4: middle estimate and measured number agree at the digits printed; the measured number falls inside the stated range.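

In this assay, pyridin-3-yl in place of thiophen-2-yl on the fluoro-bearing core gives no change at the digits printed from compound 3 to compound 4 (within the scatter), and the step carries over from the earlier core without a measurable difference: the same change on two cores in this assay, no change at the digits printed (within the scatter) from compound 1 to compound 2 and no change at the digits printed (within the scatter) from compound 3 to compound 4, 0 percentage points apart, within the scatter of two such steps.

Fluoro in place of hydrogen on an aromatic carbon likewise gives no change at the digits printed from compound 2 to compound 4 (within the scatter), and this step also carries over between the two cores: the same change on two cores in this assay, no change at the digits printed (within the scatter) from compound 1 to compound 3 and no change at the digits printed (within the scatter) from compound 2 to compound 4, 0 percentage points apart, within the scatter of two such steps.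

Among these compounds, these matches are between steps that show no change, so they show only that neither change moves the read-out on either core; they do not show that a step of real size would carry over, and a percentage at one concentration gives no potency.

The compounds shown leave open whether anything at the carbon with a double bond to nitrogen can move the value beyond the scatter, since only thiophen-2-yl and pyridin-3-yl stand there. An amine, a carboxylic acid or a longer chain in that place would test this, and a step of real size would give the first informative check of carry-over between cores.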